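Swapping the Vinyl Group on the Carbonyl Carbon

This account rests on a few compounds, and the source may have more. Where it says the series, first, only, none or still open, it means among the compounds named here.

Measured in a functional assay on HeLa cells (Homo sapiens) for antiproliferative activity, read by MTT assay, with a stated time of 72 h; a higher number here means a weaker inhibitor, a lower number a stronger inhibitor:
- Compound 1 `C=CC(=O)Nc1cccc(Oc2nc(Nc3cccc(OC)c3)nc3c2CSCC3)c1`: 28900 nM
- Compound 2 `C=CC(=O)Nc1cccc(Oc2nc(Nc3cccc(C#N)c3)nc3c2CSCC3)c1`: 34900 nM
- Compound 3 `C=CC(=O)Nc1cccc(Oc2nc(Nc3ccc(OC)cc3)nc3c2CSCC3)c1`: 20900 nM

In this assay, compound 3 stands level with the other two compounds: a 1.4-fold lower number from compound 1 to compound 3 (0.14 log units; within the scatter) and a 1.7-fold lower number from compound 2 to compound 3 (0.22 log units; within the scatter) both lie within the scatter, as does a 1.2-fold higher number from compound 1 to compound 2 (0.08 log units; within the scatter).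

Compound 4 `COc1ccc(Nc2nc3c(c(Oc4cccc(NC(=O)/C=C/C(C)C)c4)n2)CSCC3)cc1` differs from compound 3 in one place: 3-methylbut-1-en-1-yl in place of vinyl on a carbonyl carbon. In words, 3-methylbut-1-en-1-yl stands in place of vinyl on a carbonyl carbon. Among the measured compounds shown here, none of the measured steps touches that place. All three change the substituted phenyl group on a nitrogen on an aromatic ring, so they give no direct size for this change, and the data hold no test of it. With only those small steps to go on, no change beyond the scatter is expected, and the estimate starts from compound 3 at 20900 nM. The expected result is a 1.3-fold higher number from compound 3 to compound 4 (0.11 log units; within the scatter). Compound 4 is estimated at 27000 nM, with an expected range of 12000 nM to 60000 nM.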

Compound 4, half-maximal inhibitory concentration: 22900 nM
The estimate for compound 4 lay 1.2-fold (0.07 log units) above the measured number; the range from low to high includes it.
By their numbers in this assay, from the lowest: compounds 3, 4, 1 and 2 (each within the scatter of the next).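

In this assay, among the compounds shown here, 3-methylbut-1-en-1-yl in place of vinyl on the carbonyl carbon gives a 1.1-fold higher number from compound 3 to compound 4 (0.04 log units; within the scatter), the first direct reading at this position, which the earlier steps left untouched. The group grows from 2 heavy atoms to 5, all carbon, with its double bond kept, and the step still stays within the scatter. No supporting data shown here explain this result.

As far as these compounds go, all four compounds carry a hydrocarbon group with a double bond on this carbonyl carbon, so it remains open how a saturated ethyl group or a chain ending in a dimethylamino group would read there. For the compounds shown here, with every step so far within the scatter, it also remains open which change to these compounds, if any, would move the number beyond it.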